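Aryl in place of benzyl on the ring nitrogen

The compounds below may be only part of what the source reports. "The series", "measured", "known", "first", "only" and "open" are said of these compounds alone.

Compound 1 `COc1ccccc1-n1cc(COc2cccc3cnc(Nc4cccc(Cl)c4)nc23)nn1`: > 25000 nM
Compound 2 `Clc1cccc(Nc2ncc3cccc(OCc4cn(Cc5c(Cl)cccc5Cl)nn4)c3n2)c1`: 5000 nM
Compound 3 `COc1cccc(-n2cc(COc3cccc4cnc(Nc5cccc(Cl)c5)nc34)nn2)c1`: > 25000 nM

Among the measured compounds shown here, in a functional assay on NCI-H727 cells (Homo sapiens) for cytotoxicity, read by cell counting, with a stated time of 48 h (on this read-out lower numbers stand for stronger inhibition and higher numbers for weaker inhibition), compound 2 gives 5000 nM, the only number in the set. Compound 1 gives only a limit, > 25000 nM. Compound 3 likewise gives only a limit, > 25000 nM. Both sit at the limit of > 25000 nM in this assay, at which 2 of the 3 values shown sit. The steps read an at least 5.0-fold lower number from compound 1 to compound 2 (0.69 log units; beyond the scatter) and an at least 5.0-fold higher number from compound 2 to compound 3 (0.69 log units; beyond the scatter): each time 2,6-dichlorobenzyl is exchanged for a 2-methoxyphenyl or 3-methoxyphenyl on the ring nitrogen, the number rises past the limit. Compound 4 `Clc1cccc(Nc2ncc3cccc(OCc4cn(-c5cc(Cl)cc(Cl)c5)nn4)c3n2)c1` carries 3,5-dichlorophenyl in place of 2,6-dichlorobenzyl on an aromatic nitrogen. The change again removes 2,6-dichlorobenzyl for a directly attached phenyl, so a step of similar size toward weaker inhibition is expected, a 4.0-fold higher number from compound 2 to compound 4 (0.60 log units; beyond the scatter), most likely ending at a limit. Compound 4 is estimated at 20000 nM, between 5000 nM and 60000 nM.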

Compound 4, half-maximal inhibitory concentration: 7000 nM
For compound 4 the middle estimate is 2.9-fold (0.46 log units) above the measured one; the range from low to high includes it.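

A directly attached phenyl on the ring nitrogen does not by itself cost activity: in this assay, 3,5-dichlorophenyl in place of 2,6-dichlorobenzyl gives a 1.4-fold higher number from compound 2 to compound 4 (0.15 log units; within the scatter). Among the directly attached phenyls, the substituents count, with 3,5-dichlorophenyl giving an at least 3.5-fold lower number from compound 3 to compound 4 (0.55 log units; beyond the scatter) and an at least 3.5-fold lower number from compound 1 to compound 4 (0.55 log units; beyond the scatter). Compound 1 and compound 3 remain limits of the assay, not numbers: the limit of > 25000 nM in this assay, at which 2 of the 4 values shown sit.

From the compounds shown here alone, how a carboxylic acid or an amine on this phenyl would read stays open. So does the reading of a longer chain on the ring nitrogen.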